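This account rests on a few compounds, and the source may have more. Where it says the series, first, only, none or still open, it means among the compounds named here.

Measured compounds in an in vitro functional assay on CHO-CREluc cells for antagonist activity at growth hormone secretagogue receptor type 1 (Homo sapiens), read by a luciferase reporter, with a stated time of 4 h; a higher number here means a weaker inhibitor, a lower number a stronger inhibitor:
- compound 1 `CN(C)CCN(C)CC(=O)NC1(c2ccc(Cl)cc2)C(=O)Nc2cc(Cl)c(Cl)cc21`: > 10000 nM, a limit of the assay
- compound 2 `Cc1cc2c(cc1Cl)NC(=O)C2(NC(=O)CN1CCN(c2ccncc2)CC1)c1ccc(Cl)cc1`: > 10000 nM, a limit of the assay

Compound 2 stands at the upper limit of this assay; its value is a limit and not a number. Compound 1 also sits at a limit of this assay. Among the measured compounds shown here, both values shown for the series so far are limits, as summarised in the limit of > 10000 nM in this assay, at which 2 of the 2 values shown sit, so no measured step exists and no ordering between compound 2 and compound 1 can be drawn.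

The next compound, compound 3 `Cc1cc2c(cc1Cl)NC(=O)C2(NC(=O)CN1CCNCC1)c1ccc(Cl)cc1`, differs from compound 2 in one place: hydrogen in place of pyridin-4-yl on an amine nitrogen in a ring. For the measured compounds named here, with both known values at the limit, there is no measured step on which to size this change; the expectation is that compound 3 again stays near the limit, the step that the limit leaves unreadable from compound 2 to compound 3 being expected to lie within the scatter rather than beyond it. The estimate for compound 3 in this assay is 15000 nM, with a range from 3000 nM to 80000 nM, and most likely the assay will again report only a limit.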

Compound 3, half-maximal inhibitory concentration: > 10000 nM
Compound 3: no number, only a limit (the forecaster's own chance of this, stated with the estimate: 75%); the middle value lies beyond the limit too.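

In this assay compound 3 gives > 10000 nM, a limit of the assay and not a number. Compound 2 also sits at a limit, so no step can be read between compound 2 and compound 3 for hydrogen in place of pyridin-4-yl. The compounds shown leave open what any change around the shared core does to a measurable inhibitory value in this assay: the limit of > 10000 nM in this assay, at which 3 of the 3 values shown sit.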